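The compounds below may be only part of what the source reports. "The series", "measured", "known", "first", "only" and "open" are said of these compounds alone.

Compound 1 `CN(C)C(=O)c1cc2cnc(Nc3ccc(NC(=O)C4(C(=O)Nc5cccc(O)c5)CC4)cc3)nc2n1C1CCCC1` gives 78.5%
Compound 2 `CN(C)C(=O)c1cc2cnc(Nc3ccc(NC(=O)C4(C(=O)Nc5cccc(Cl)c5)CC4)cc3)nc2n1C1CCCC1` gives 84.1%

Among the compounds with values here, in a functional assay on NCI-H1299 cells (Homo sapiens) for inhibition, read by CCK-8 assay, with a stated time of 72 h, tested at 10 uM (a lower number here means less inhibition of growth, a higher number more inhibition of growth at the concentration tested), compound 2 stands at 84.1% and lies within the scatter of compound 1, the only other compound with a number so far. Compound 3 `CN(C)C(=O)c1cc2cnc(Nc3ccc(NC(=O)C4(C(=O)Nc5ccc(Br)cc5)CC4)cc3)nc2n1C1CCCC1` has not been measured yet. It carries 4-bromophenyl in place of 3-chlorophenyl on an amide-type nitrogen and keeps everything else. Within the data shown here, only one measured step bears on this change, and only loosely: a number 5.6 percentage points higher from compound 1 to compound 2 (within the scatter), with chloro in place of hydroxy on an aromatic carbon of that same ring. Among the measured compounds shown here, no measured pair swaps chloro for bromo or moves a group around that ring. No step beyond the scatter is therefore expected, and the estimate means a number 4.1 percentage points lower from compound 2 to compound 3 (within the scatter) as the expected change. Compound 3 is estimated at 80% with 65% to 92% as the expected range.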

Compound 3, percent growth inhibition at one concentration: 76.9%
Beside the measured number, compound 3's estimate is 3.1 percentage points above it, and the stated range covers the measured number.
By their numbers in this assay, from the lowest: compounds 3, 1 and 2 (each within the scatter of the next).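

In this assay, 4-bromophenyl in place of 3-chlorophenyl on the amide-type nitrogen gives (a number 7.2 percentage points lower from compound 2 to compound 3 (within the scatter)), and 4-bromophenyl in place of 3-hydroxyphenyl gives (a number 1.6 percentage points lower from compound 1 to compound 3 (within the scatter)). The position has now carried a third group, with a different substituent at a different ring position, and neither new step leaves the scatter, so the hydroxy, chloro and bromo compounds cannot be told apart in this read-out at the single concentration tested. No measurement on hand offers an explanation for these numbers.

The step from compound 2 to compound 3 changes both the halogen and its place on the ring, so the two changes cannot be separated, and 4-chlorophenyl or 3-bromophenyl would be needed to do that. From the compounds shown here alone, whether an amine or a carboxylic acid on this ring would move the number beyond the scatter also stays open.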